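Methyl for Methoxy on the Sulfonyl-Bearing Ring

This account rests on a few compounds, and the source may have more. Where it says the series, first, only, none or still open, it means among the compounds named here.

The series shares one core and varies only the aryl group on the sulfonyl sulfur. Compound 1 `COc1cc2c(Oc3ccc(NC(=O)/C=C/S(=O)(=O)c4ccccc4OC)cc3F)ccnc2cc1OCCCN1CCCCC1` carries a 2-methoxyphenyl there, and in a functional assay on HT-29 cells (Homo sapiens) for cytotoxicity, read by MTT assay, with a stated time of 72 h (on this read-out higher numbers stand for weaker inhibition and lower numbers for stronger inhibition), compound 1 gives 660 nM. Compound 2 `COc1ccc(S(=O)(=O)/C=C/C(=O)Nc2ccc(Oc3ccnc4cc(OCCCN5CCCCC5)c(OC)cc34)c(F)c2)cc1` moves the methoxy to give a 4-methoxyphenyl, and in this assay compound 2 gives 1650 nM; the step of a 2.5-fold higher number from compound 1 to compound 2 (0.40 log units; beyond the scatter) is modest but beyond the scatter, which leaves compound 2 with the highest of the two numbers recorded so far.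

Compound 3 `COc1cc2c(Oc3ccc(NC(=O)/C=C/S(=O)(=O)c4ccc(C)cc4)cc3F)ccnc2cc1OCCCN1CCCCC1` departs from compound 2 by a single change: methyl in place of methoxy on an aromatic carbon. Within the data shown here, the only measured step, from compound 1 to compound 2, concerns where the methoxy sits on that ring, not its replacement by methyl, so it bears on compound 3 only loosely and offers no direction. On that basis the expected step is about a 1.2-fold lower number from compound 2 to compound 3 (0.07 log units; within the scatter). The estimate for compound 3 in this assay is therefore 1400 nM, with a range from 500 nM to 4000 nM.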

Compound 3, half-maximal inhibitory concentration: 4230 nM
The estimate for compound 3 lay 3.0-fold (0.48 log units) below the measured number, and the stated range ends below it.
By their numbers in this assay, from the lowest: compound 1; then compound 2; then compound 3.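

In this assay, the change from methoxy to methyl on the aromatic carbon para to a large group gives a 2.6-fold higher number from compound 2 to compound 3 (0.41 log units; beyond the scatter) and lies beyond the scatter, so the group at this place matters as well as where the methoxy sits. Measured against the 2-methoxyphenyl group, the 4-methylphenyl group gives a 6.4-fold higher number from compound 1 to compound 3 (0.81 log units; beyond the scatter) and is the largest step among these compounds, and all three sit apart in this assay, with the 2-methoxyphenyl compound giving the lowest number and the 4-methylphenyl compound the highest. No measurement offered here gives a reason for the loss that follows from removing the methoxy oxygen in favour of a plain methyl.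

The compounds shown leave open whether the rise in the number seen with methyl would hold for other groups on that carbon, such as an amine, a chlorine atom or a longer alkoxy chain. Among these compounds, they also leave open whether methyl would fare any differently on the carbon that carries the methoxy in compound 1, where the methoxy gives the lowest number so far.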